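A few compounds are considered here, and "the series" means these few. Any claim that something is new, unique, unknown or untested is made for them only; others in the source may bear on it.

Series notes. Compound 3 `COc1ccc(C(=O)c2cc(OC)c(OC)c(OC)c2)c(NC(=O)CN)c1` in a functional assay on HCT-8 cells (Homo sapiens) for antiproliferative activity, read by MTT assay, with a stated time of 48 h (a lower number here means a stronger inhibitor, a higher number a weaker inhibitor), gives 330 nM. Compound 1 `CNCC(=O)Nc1cc(OC)ccc1C(=O)c1cc(OC)c(OC)c(OC)c1` gives 780 nM. The change between them is methyl in place of hydrogen on an amine nitrogen, and it brings a 2.4-fold higher number from compound 3 to compound 1 (0.37 log units; beyond the scatter). Compound 2 `C=C(c1ccc2c(c1)C=CC(C)(C)O2)c1ccc(OC)cc1NC(=O)CN` gives 220 nM; the difference between the core of compound 2 and the core of compound 3 is not broken down here. Compound 2 and compound 3 lie within the scatter of each other; compound 1 sits beyond both.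

Compound 4 `C=C(c1ccc2c(c1)C=CC(C)(C)O2)c1ccc(OC)cc1NC(=O)CNC` is not yet measured. It differs from compound 2 by methyl in place of hydrogen on an amine nitrogen, the same change seen from compound 3 to compound 1, at the same place. Among the measured compounds shown here, with only that one precedent, the expectation is a step of like size. Resting on a 2.4-fold higher number from compound 3 to compound 1 (0.37 log units; beyond the scatter), the expected step is a 2.4-fold higher number from compound 2 to compound 4 (0.38 log units; beyond the scatter). Compound 4 is thus estimated at 530 nM, between 250 nM and 1100 nM.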

Compound 4, half-maximal inhibitory concentration: 590 nM
Beside the measured number, compound 4's estimate is 1.1-fold (0.05 log units) below it; low and high end bracket the measured number.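

Methyl in place of hydrogen on the amine nitrogen again gives a weaker result in this assay, with a 2.7-fold higher number from compound 2 to compound 4 (0.43 log units; beyond the scatter). Compared with the earlier step, the change carries from one core to the other with no difference that can be told apart: the same change on two cores in this assay, a 2.4-fold higher number (0.37 log units; beyond the scatter) from compound 3 to compound 1 and a 2.7-fold higher number (0.43 log units; beyond the scatter) from compound 2 to compound 4, 1.1-fold (0.05 log units) apart, within the scatter of two such steps. Among the compounds shown here, this rests on only two pairs in a single assay, so it shows a shared step for these two cores and does not show why the step arises or whether it holds on any other core.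

The compounds shown leave open what an ethyl group on the same nitrogen or a dimethylamino end would do. On these data alone, a longer chain in place of the aminomethyl also remains open.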